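Aryl Exchange on a Shared Core: Compound 3 to Compound 4

The source may report more compounds than this note shows. Statements on the series, on what has been measured and on what is new or still open speak of the compounds shown alone.

Three analogues built on one shared core were measured in a functional assay on HCT-15 cells (Homo sapiens) for inhibition, read by sulforhodamine B assay, with a stated time of 48 h, tested at 10 uM; a lower number here means less inhibition, a higher number more inhibition at the concentration tested (going by the name of the read-out). Compound 1 `Brc1cn2ccnc2c(-c2ccc3ncn(C4CCCCC4)c3c2)n1` gives 13.1%, compound 2 `CC(=O)c1ccc(-c2cn3ccnc3c(-c3ccc4ncn(C5CCCCC5)c4c3)n2)cc1` gives 18.8%, and compound 3 `COc1ccccc1-c1cn2ccnc2c(-c2ccc3ncn(C4CCCCC4)c3c2)n1` gives 33.6%, the highest of the three numbers, with both other compounds beyond the scatter below it. Compound 4 `FC(F)(F)c1cccc(-c2cn3ccnc3c(-c3ccc4ncn(C5CCCCC5)c4c3)n2)c1` has not been measured; it differs from compound 3 in one place: 3-(trifluoromethyl)phenyl in place of 2-methoxyphenyl on an aromatic carbon. Among the measured compounds shown here, the steps that bear on this change are a number 5.7 percentage points higher from compound 1 to compound 2 (within the scatter), a number 20.5 percentage points higher from compound 1 to compound 3 (beyond the scatter) and a number 14.8 percentage points higher from compound 2 to compound 3 (beyond the scatter), so exchanging the group on this carbon has moved the read-out by at most modest amounts. Because compound 3 holds the top value 33.6%, the step of a number 11.6 percentage points lower from compound 3 to compound 4 (beyond the scatter) is expected to be a modest fall. Compound 4 is therefore estimated at 22%, within a range from 8% to 40%.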

Compound 4, a percentage reported as inhibition, at one concentration (the size of the read-out at that concentration, not a potency): 0.36%
Compound 4: middle estimate off by 21.6 percentage points, on the high side; the whole stated range lies above it.
By their numbers in this assay, from the lowest: compound 4; then compounds 1 and 2 (each within the scatter of the next); then compound 3.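

Among the compounds shown here, the exchange on this carbon can be far larger than the earlier compounds suggested, with a number 33.2 percentage points lower from compound 3 to compound 4 (beyond the scatter), the only large step at this position. An aryl group here also need not match the bromo compound: 3-(trifluoromethyl)phenyl gives a number 12.7 percentage points lower from compound 1 to compound 4 (beyond the scatter), and it also falls short of 4-acetylphenyl, with a number 18.4 percentage points lower from compound 2 to compound 4 (beyond the scatter). Nothing available explains these falls.

The compounds shown leave open whether the fall goes with the trifluoromethyl group itself or with its place on the phenyl ring. From the compounds shown here alone, how a phenyl ring carrying an amine or a carboxylic acid would read on this carbon also remains open.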